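4-Hydroxypiperidin-1-yl in place of 4-methylpiperazin-1-yl

The compounds below may be only part of what the source reports. "The series", "measured", "known", "first", "only" and "open" are said of these compounds alone.

Going by the values given here, in a physicochemical assay for solubility, in phosphate buffer, measured as kinetic solubility, with a stated time of 24 h, at pH 7.4 (on this read-out lower numbers stand for lower solubility and higher numbers for higher solubility), compound 2 `CC(C)CN(Cc1ccc(N2CCN(C)CC2)cc1)S(=O)(=O)Cc1ccccc1` gives 60000 nM, the only true number so far. Compound 1 `CC(C)CN(Cc1ccc(N2CCN(S(C)(=O)=O)CC2)cc1)S(=O)(=O)Cc1ccccc1` gives <= 1000 nM, which is a limit of the assay and not a number. Compound 3 `CC(C)CN(Cc1ccc(N2CCC(O)CC2)cc1)S(=O)(=O)Cc1ccccc1` carries 4-hydroxypiperidin-1-yl in place of 4-methylpiperazin-1-yl on an aromatic carbon. Among the compounds with values here, one measured step bears on this change: an at least 60-fold higher number from compound 1 to compound 2 (1.77 log units; beyond the scatter), a large step made within the same ring substituent. It shows that this assay can move far with edits at this end of the molecule, but it does not cover the new group. With that step ending on the value of compound 2, a moderate drop is expected rather than a further rise. The expected step is a 4.0-fold lower number from compound 2 to compound 3 (0.60 log units; beyond the scatter). For compound 3 the estimate is 15000 nM, with an expected range from 2500 nM to 60000 nM.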

Compound 3, solubility: 7000 nM
For compound 3 the middle estimate is 2.1-fold (0.33 log units) above the measured one, and the stated range covers the measured number.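

In this assay, 4-hydroxypiperidin-1-yl in place of 4-methylpiperazin-1-yl on an aromatic carbon gives an 8.6-fold lower number from compound 2 to compound 3 (0.93 log units; beyond the scatter), so this position responds to a change of the ring itself as well as to a change of the substituent on its nitrogen. Against the methylsulfonyl analogue the same ring gives an at least 7.0-fold higher number from compound 1 to compound 3 (0.84 log units; beyond the scatter), which leaves compound 3 between the other two compounds. Compound 1 stands at a limit of the assay and not at a number, so the full size of that second step stays unknown: the limit of <= 1000 nM in this assay, at which 1 of the 3 values shown sits.

The compounds shown do not separate the loss of the methyl-bearing ring nitrogen from the gain of the hydroxyl. From the compounds shown here alone, how a morpholine ring, or a piperidine carrying a primary amine in place of the hydroxyl, would read in this assay remains open.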